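Mirror image of compound 2: the enantiomer question

A few compounds are considered here, and "the series" means these few. Any claim that something is new, unique, unknown or untested is made for them only; others in the source may bear on it.

The set comprises three compounds sharing one core. Compound 1 `CO[C@H]1CC[C@H](CNc2cc(NCc3cnccc3C(F)(F)F)ncc2C#N)CC1` and compound 2 `CC1(C)C[C@H](Nc2cc(NCc3cnccc3C(F)(F)F)ncc2C#N)CC(C)(C)[C@@H]1O` have been measured in an assay on isolated protein for inhibition of protein kinase C delta type (Homo sapiens), read by TR-FRET, with a stated time of 2 h (on this read-out lower numbers stand for stronger inhibition and higher numbers for weaker inhibition), while compound 3 `CC1(C)C[C@H](Nc2cc(NCc3cnccc3C(F)(F)F)ncc2C#N)CC(C)(C)[C@H]1O` has not. For compound 1 the assay reports only a limit, > 10000 nM, and not a number. For the measured compounds named here, compound 2 gives 700 nM, the only number among the values shown. Going by the values given here, the one other value is a limit, as noted for compound 1 in the limit of > 10000 nM in this assay, at which 1 of the 2 values shown sits. Compound 3 differs from compound 2 as follows: the two compounds have the same atoms and bonds and differ only in configuration as drawn: 2 of 2 stereo elements differ (all stereocentres are inverted: mirror images); a stereocentre at a saturated ring carbon is drawn s in compound 2 and r in compound 3; a stereocentre at a saturated ring carbon is drawn s in compound 2 and r in compound 3. Among the compounds with values here, no step between two measured compounds is available, so the size of this change can only be expected rather than read from a neighbour. Inversion of every stereocentre is a change that can move a value in either direction, and nothing among the measured compounds favours one side. The account settles on a loss beyond the scatter, with a wide range: compound 3 is expected to give 2500 nM, between 500 nM and 10000 nM, which means an expected step of a 3.6-fold higher number from compound 2 to compound 3 (0.55 log units; beyond the scatter).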

Compound 3, half-maximal inhibitory concentration: 500 nM
For compound 3 the middle estimate is 5.0-fold (0.70 log units) above the measured one; measured number inside the range.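

For the compounds shown here, for the first time in this set a step can be read in this assay, and it is small: inversion of both stereocentres at the saturated ring carbons gives a 1.4-fold lower number from compound 2 to compound 3 (0.15 log units; within the scatter). The configuration drawn at these two ring carbons therefore does not separate the two mirror images on this read-out, and no other change in the structures enters the comparison: the fact that compounds 2 and 3 differ only in the configuration as drawn. Going by these compounds alone, compound 1 gives > 10000 nM in this assay, which is a limit and not a number, so no step to it can be read.

The compounds shown leave open what a form with only one of the two ring stereocentres inverted would give on this read-out, as both centres change together in this pair. They also leave open what an amine or a carboxylic acid in place of the hydroxyl group would give, and whether the absence of a configuration effect would hold with such a group on the ring.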